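Aminopropylamino Chain Replacing an Azide on a Dialkylated Core

The compounds below may be only part of what the source reports. "The series", "measured", "known", "first", "only" and "open" are said of these compounds alone.

Compound 1 `CCCCCCCCCO[C@@H]1[C@@H](N)[C@@H](OCC(O)CNCCCO)O[C@H](CN)[C@H]1OCCCCCCCCC`: 13.7%
Compound 2 `CCCCCCCCCO[C@@H]1[C@@H](N)[C@@H](OC[C@H](O)CN=[N+]=[N-])O[C@H](CN)[C@H]1OCCCCCCCCC`: 5.9%
Compound 3 `CCCCCCCCCO[C@@H]1[C@@H](N)[C@@H](O[C@H]2[C@H](O)[C@@H](OCCCCCCCCC)[C@H](N)C[C@@H]2N)O[C@H](CN)[C@H]1O`: 38.8%

In a toxicity assay on the whole organism (J774 cells) for cytotoxicity, with Mus musculus as the target, read by MTT assay, with a stated time of 24 h, tested at 30 uM (on this read-out lower numbers stand for a stronger effect and higher numbers for a weaker effect at the one concentration tested), compound 2 gives 5.9%, the low end of the three numbers shown. Within the data shown here, compound 1, at 13.7%, lies within the scatter of compound 2, whereas compound 3, at 38.8%, lies beyond it; compound 3 differs from the others in more than one place, so no single step connects it.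

Compound 4 `CCCCCCCCCO[C@@H]1[C@@H](N)[C@@H](OCC(O)CNCCCN)O[C@H](CN)[C@H]1OCCCCCCCCC` is the next compound. The change from compound 2 is 2-((3-aminopropyl)amino)-1-hydroxyethyl in place of 2-azido-1-hydroxyethyl on a saturated chain carbon bound to an oxygen on a saturated carbon. Among the measured compounds shown here, the one measured step that bears on it is a number 7.8 percentage points lower from compound 1 to compound 2 (within the scatter), a change within the scatter between an azide and a chain carrying an amine and a hydroxyl at the same place. Compound 4 carries a related chain, with an amine in place of that terminal hydroxyl, so a step of similar size and direction is expected, that is a number 6.1 percentage points higher from compound 2 to compound 4 (within the scatter), not beyond the scatter. Compound 4 is therefore estimated at 12%, with a range of 3% to 28%.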

Compound 4, a percentage reported as activity, at one concentration (the size of the read-out at that concentration, not a potency): 71.6%
Estimate against measurement, compound 4: 59.6 percentage points below; the measured number lies above the stated range.
By their numbers in this assay, from the lowest: compounds 2 and 1 (each within the scatter of the next); then compound 3; then compound 4.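

In this assay, compound 1 and compound 2 had stayed within the scatter of each other, so the group at this place seemed to matter little, yet 2-((3-aminopropyl)amino)-1-hydroxyethyl in place of 2-azido-1-hydroxyethyl gives a number 65.7 percentage points higher from compound 2 to compound 4 (beyond the scatter), a much weaker effect. The closer comparison, amino in place of hydroxy on a saturated chain carbon, three bonds along the chain from an amine nitrogen, gives a number 57.9 percentage points higher from compound 1 to compound 4 (beyond the scatter), so among these compounds the large difference goes with that one amino group rather than with the chain as a whole. Nothing available accounts for the size of this step.

From the compounds shown here alone, it remains open whether a dimethylamino group or a carboxylic acid in the same place would read like the amino group or like the hydroxy group. Also open, going by these compounds, is what a longer chain carrying the same amino group would give.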